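From butoxycarbonyl to cyclohexylcarbamoyl on compound 1

The compounds below may be only part of what the source reports. "The series", "measured", "known", "first", "only" and "open" are said of these compounds alone.

Compound 1 `CCCCOC(=O)Nc1ccc(S(=O)(=O)N2C[C@H](c3ccccc3)NC2=O)cc1CC` is the anchor of the set. In a functional assay on HCT-116 cells (Homo sapiens) for cytotoxicity, read by MTT assay (on this read-out higher numbers stand for weaker inhibition and lower numbers for stronger inhibition), compound 1 gives 200 nM, the lowest of the two numbers available. Among the measured compounds shown here, compound 2 `CCOC(=O)Nc1ccc(S(=O)(=O)N2C(=O)N[C@@H](c3ccccc3)C2C)cc1Cl` gives 5500 nM in this assay, a gap from compound 1 that lies beyond the scatter; the two structures differ in several places, so no single step is defined between them. Compound 3 `Cc1cc(S(=O)(=O)N2C(=O)N[C@@H](c3ccccc3)C2C)ccc1NC(=O)c1ccc([N+](=O)[O-])cc1` gives no number but a limit in this assay, namely > 10000 nM, which is the limit of > 10000 nM in this assay, at which 1 of the 3 values shown sits.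

The open compound is compound 4 `CCc1cc(S(=O)(=O)N2C[C@H](c3ccccc3)NC2=O)ccc1NC(=O)NC1CCCCC1`. It differs from compound 1 in one place: cyclohexylamino in place of butoxy on a carbonyl carbon. Cut one bond further out, this reads butoxycarbonyl to cyclohexylcarbamoyl. For the measured compounds named here, no measured pair in the set isolates this change, so the size of the step is untested. The expected step in this assay is a 1.5-fold higher number from compound 1 to compound 4 (0.18 log units; within the scatter), with either direction possible and a change within the scatter most likely. Compound 4 is accordingly estimated at 300 nM, with a range from 80 nM to 1500 nM.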

Compound 4, half-maximal inhibitory concentration: 300 nM
Compound 4: middle estimate and measured number agree at the digits printed, and the stated range covers the measured number.
By their numbers in this assay, from the lowest: compounds 1 and 4 (each within the scatter of the next); then compound 2. At a limit, above all of these: compound 3.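

Among the compounds shown here, exchanging butoxy for cyclohexylamino on this carbonyl carbon gives a 1.5-fold higher number from compound 1 to compound 4 (0.18 log units; within the scatter) in this assay, the first step that isolates one place. The exchange brings in a six-membered non-aromatic ring and a hydrogen-bond donor and removes an open chain and a hydrogen-bond acceptor, yet the numbers of the two compounds lie within the scatter of each other. In this assay, then, this position accepts both the (butoxycarbonyl)amino and the (cyclohexylcarbamoyl)amino group, a statement that rests on this single pair.

As far as these compounds go, whether an anilino group, a morpholine or a chain ending in a carboxylic acid on the same carbonyl carbon would keep the number in this range remains open. Nothing in the data shown bears on a cause for this step.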